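Pyridin-3-yl in place of 2-nitrophenyl: working notes

The source may hold more compounds than are shown below. What is called first, only, known or untested is meant among the compounds shown, and "the series" means these compounds.

Measured so far in a functional assay on B16-F10 cells (Mus musculus) for antiproliferative activity, read by MTT assay, with a stated time of 48 h (a lower number here means a stronger inhibitor, a higher number a weaker inhibitor), and nothing else:
- compound 1 `CC(=O)N1N=C(c2ccc3ccccc3c2)OC1c1ccc(Cl)cc1` gives 2.48 ug/mL
- compound 2 `CC(=O)N1N=C(c2ccc3ccccc3c2)OC1c1ccccc1[N+](=O)[O-]` gives 9.01 ug/mL

Compound 2 holds the higher of the two numbers and is thus the weaker inhibitor of the two. The next structure is compound 3 `CC(=O)N1N=C(c2ccc3ccccc3c2)OC1c1cccnc1` with pyridin-3-yl in place of 2-nitrophenyl on a saturated ring carbon, and the change counts as pyridin-3-yl in place of 2-nitrophenyl on a saturated ring carbon in full.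

Going by the values given here, one measured step bears on this, a 3.6-fold higher number from compound 1 to compound 2 (0.56 log units; beyond the scatter) and it was made on the same saturated ring carbon. It shows that this assay responds to a change at this place, though its size is modest. Among the compounds with values here, no compound with pyridin-3-yl has been measured, so the direction rests on little. With compound 2 at 9.01 ug/mL as the higher number, a modest move downward seems more likely than a further rise, and the step may not clear the scatter.

The expected step is a 1.5-fold lower number from compound 2 to compound 3 (0.18 log units; within the scatter) in this estimate. For compound 3 the estimated value is 6 ug/mL with an expected range from 2 ug/mL to 18 ug/mL in this assay for now.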

Compound 3, half-maximal inhibitory concentration: 3.06 ug/mL
The estimate for compound 3 lay 2.0-fold (0.29 log units) above the measured number; low and high end bracket the measured number.
By their numbers in this assay, from the lowest: compounds 1 and 3 (each within the scatter of the next); then compound 2.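

The change from 2-nitrophenyl to pyridin-3-yl on the saturated ring carbon gives, in this assay, a clear response (a 2.9-fold lower number from compound 2 to compound 3 (0.47 log units; beyond the scatter)), so this position has now answered to a second replacement and not only to the earlier one (a 3.6-fold higher number from compound 1 to compound 2 (0.56 log units; beyond the scatter)). Set against 4-chlorophenyl, pyridin-3-yl gives a 1.2-fold higher number from compound 1 to compound 3 (0.09 log units; within the scatter), so a ring with one hetero atom and a carbon-only ring bearing chlorine cannot be told apart here, while 2-nitrophenyl alone stands apart, with steps beyond the scatter to both other groups. Nothing available explains why these three groups fall as they do.

The compounds shown leave open whether an aromatic ring is needed at this carbon at all, or whether a saturated amine such as piperidin-4-yl, or a phenyl ring carrying a carboxylic acid, would stay level with compound 1 and compound 3. They also leave open whether these steps would read the same with a propanoyl group in place of the acetyl group on the neighbouring ring atom.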